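Swapping the Benzylamine Linker for a Phenoxy Ether

The source may report more compounds than this note shows. Statements on the series, on what has been measured and on what is new or still open speak of the compounds shown alone.

Compound 2 `Nc1cc(N)c2nc(-c3ccccc3)c(NCc3ccc(F)cc3)nc2c1` gives 5010 nM in a functional assay on SNB-75 cells (Homo sapiens) for inhibition, read by sulforhodamine B assay, with a stated time of 48 h (on this read-out higher numbers stand for weaker inhibition of growth and lower numbers for stronger inhibition of growth), the lowest of the three numbers measured. Compound 1 `COc1ccc(CNc2nc3cc(N)cc(N)c3nc2-c2ccccc2)cc1OC` gives 39800 nM in this assay, and compound 3 `COc1ccc(CNc2nc3cc(N)cc(N)c3nc2-c2ccccc2)cc1` gives 30200 nM. The measured steps change only the groups on the aryl ring: a 7.9-fold lower number from compound 1 to compound 2 (0.90 log units; beyond the scatter), a 6.0-fold higher number from compound 2 to compound 3 (0.78 log units; beyond the scatter) and a 1.3-fold lower number from compound 1 to compound 3 (0.12 log units; within the scatter). Compound 4 `Nc1cc(N)c2nc(-c3ccccc3)c(Oc3ccc(F)cc3)nc2c1` differs from compound 2 in another way: 4-fluorophenoxy in place of (4-fluorobenzyl)amino on an aromatic carbon. For the measured compounds named here, no measured step alters the link between this ring and the shared core, so the data give no direct guide. The expectation is therefore a step of uncertain direction, most likely a 1.6-fold higher number from compound 2 to compound 4 (0.20 log units; within the scatter) in this assay. Compound 4 is estimated at 8000 nM, with a range from 2500 nM to 30000 nM.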

Compound 4, concentration for total growth inhibition: 49000 nM
Compound 4: the middle estimate sits 6.1-fold (0.79 log units) below what was measured, outside the stated range (above it).
By their numbers in this assay, from the lowest: compound 2; then compounds 3, 1 and 4 (each within the scatter of the next).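

In this assay putting 4-fluorophenoxy in place of (4-fluorobenzyl)amino brings a 9.8-fold higher number from compound 2 to compound 4 (0.99 log units; beyond the scatter) and so shows that the link between the fluorinated ring and the shared core also bears on the read-out, not only the groups on that ring. The hydrogen-bond donor and the saturated chain carbon leave together, so this one step cannot separate them. No measurement available here gives a reason for the step. Still open, on these data alone, is whether a methylated amine, a methylene link or a sulfur link would track compound 2 or compound 4.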